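Phenethyl in place of 4-ethoxyphenyl on the fused core

The source may report more compounds than this note shows. Statements on the series, on what has been measured and on what is new or still open speak of the compounds shown alone.

In a functional assay on L1210 cells (Mus musculus) for inhibition, read by cell counting, with a stated time of 2 days (on this read-out higher numbers stand for weaker inhibition and lower numbers for stronger inhibition), compound 1 `COc1ccc(-c2nn3cc(-c4cccc(N)c4)nc3s2)cc1OC` gives 16000 nM. Compound 2 `C=C(Br)C(=O)Nc1cccc(-c2cn3nc(-c4ccc(OCC)cc4)sc3n2)c1` gives 790 nM in this assay, the lowest of the two numbers; the higher number of compound 1 lies beyond the scatter. Compound 3 `C=C(Br)C(=O)Nc1cccc(-c2cn3nc(CCc4ccccc4)sc3n2)c1` is not yet measured. Its change from compound 2 is phenethyl in place of 4-ethoxyphenyl on an aromatic carbon. Within the data shown here, no measured pair isolates a change at this position, so the size of the step is uncertain. A modest shift toward weaker inhibition is expected, a 2.0-fold higher number from compound 2 to compound 3 (0.31 log units; beyond the scatter). Compound 3 is therefore estimated at 1600 nM in this assay, within a range from 500 nM to 5000 nM.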

Compound 3, half-maximal inhibitory concentration: 2200 nM
Beside the measured number, compound 3's estimate is 1.4-fold (0.14 log units) below it; measured number inside the range.
By their numbers in this assay, from the lowest: compound 2; then compound 3; then compound 1.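

In this assay, the step of a 2.8-fold higher number from compound 2 to compound 3 (0.44 log units; beyond the scatter) gives the first measured read on this aromatic carbon of the five-membered ring. The position tolerates phenethyl in place of 4-ethoxyphenyl with only a modest loss of inhibition, although the step lies beyond the scatter. The swap alters both the link to the benzene ring and the ethoxy group, and no data here separate these changes or account for the step. Still open, from the compounds shown here alone, is how a plain phenyl, a benzyl or a 4-aminophenyl group would read at this carbon.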